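The compounds below may be only part of what the source reports. "The series", "measured", "known", "first", "only" and "open" are said of these compounds alone.

Measured so far in a functional assay on MCF7 cells (Homo sapiens) for inhibition, read by sulforhodamine B assay, with a stated time of 72 h; a higher number here means a weaker inhibitor, a lower number a stronger inhibitor:

compound 1 `CC(c1ccc(-c2ccccc2)c(F)c1)c1nnc2n1N=C(c1ccccc1)CS2`: 7400 nM
compound 2 `CC(c1ccc(-c2ccccc2)c(F)c1)c1nnc2n1N=C(c1ccc(F)cc1)CS2`: 8100 nM

Compound 2 gives the higher of the two numbers, but the gap between them is only a 1.1-fold higher number from compound 1 to compound 2 (0.04 log units; within the scatter), within the scatter, so the two stand together rather than apart. That step, fluoro in place of hydrogen on an aromatic carbon, is the only one measured so far.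

Compound 3 `CC(c1ccc(-c2ccccc2)c(F)c1)c1nnc2n1N=C(c1ccc([N+](=O)[O-])cc1)CS2` differs from compound 2 by nitro in place of fluoro on an aromatic carbon, the fluoro giving way to a nitro on the same aromatic carbon, para to a large group. For the measured compounds named here, no measured pair exchanges fluoro for nitro anywhere, so the expectation rests on one indirect reading only: the step from compound 1 to compound 2, a 1.1-fold higher number from compound 1 to compound 2 (0.04 log units; within the scatter), shows that a substituent placed at this position leaves the number where it was. Carrying that over, the step to the nitro compound is expected to stay within the scatter as well, a 1.1-fold lower number from compound 2 to compound 3 (0.03 log units; within the scatter), with the range widened to allow for a group not yet seen in this series.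

For compound 3 the expected value in this assay is 7500 nM, between 3000 nM and 20000 nM.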

Compound 3, half-maximal inhibitory concentration: 7800 nM
Estimate against measurement, compound 3: 1.0-fold (0.02 log units) below; low and high end bracket the measured number.
By their numbers in this assay, from the lowest: compounds 1, 3 and 2 (each within the scatter of the next).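

In this assay, the 4-fluorophenyl to 4-nitrophenyl change gives a 1.0-fold lower number from compound 2 to compound 3 (0.02 log units; within the scatter), and nitro in place of hydrogen on the same aromatic carbon gives a 1.1-fold higher number from compound 1 to compound 3 (0.02 log units; within the scatter). This position, on an aromatic carbon para to a large group, now carries hydrogen, fluoro or nitro, and compound 1, compound 2 and compound 3 all stand within the scatter of one another, so for these three compounds the number does not separate the groups, even with nitro holding more heavy atoms than fluoro. No supporting data are available to explain why the number stays level across these groups.

Whether an amine, a carboxylic acid or a longer chain such as butyl at the same position would also leave the number in place remains open, since hydrogen, fluoro and nitro are the only groups shown there. On these data alone, the rest of the structure is the same in compound 1, compound 2 and compound 3, so the effect of a change elsewhere on the shared core also remains open, as does whether any change can move the number beyond the scatter in this assay.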